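The source may report more compounds than this note shows. Statements on the series, on what has been measured and on what is new or still open speak of the compounds shown alone.

Compound 1 `CNC(=O)c1cc(Oc2ccc(NC(=O)c3nn(-c4cccc(F)c4)c(=O)cc3C)cc2F)ccn1` and compound 2 `CNC(=O)c1cc(Oc2ccc(NC(=O)c3nn(-c4ccc(C)cc4)c(=O)cc3C)cc2F)ccn1` share a core, and in a functional assay on MCF7 cells (Homo sapiens) for cytotoxicity, read by MTT assay, with a stated time of 72 h (on this read-out higher numbers stand for weaker inhibition and lower numbers for stronger inhibition), compound 1 gives 6410 nM while compound 2 gives 8380 nM. The change between them, (4-methylphenyl in place of 3-fluorophenyl on an aromatic nitrogen), produced a 1.3-fold higher number from compound 1 to compound 2 (0.12 log units; within the scatter). Compound 3 `Cc1cc(=O)n(-c2cccc(F)c2)nc1C(=O)Nc1ccc(Oc2ncnc3ccsc23)cc1` sits on a different core; the difference between the two cores is not broken down here. In this assay compound 3 gives 6410 nM, level with compound 1 and within the scatter of compound 2. Compound 4 `Cc1ccc(-n2nc(C(=O)Nc3ccc(Oc4ncnc5ccsc45)cc3)c(C)cc2=O)cc1` is compound 3 with the same change, (4-methylphenyl in place of 3-fluorophenyl on an aromatic nitrogen). Because the earlier step was a 1.3-fold higher number from compound 1 to compound 2 (0.12 log units; within the scatter), the step from compound 3 to compound 4 is expected to be of similar size, a 1.2-fold higher number from compound 3 to compound 4 (0.10 log units; within the scatter). Compound 4 is therefore estimated at 8000 nM, expected between 4000 nM and 16000 nM.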

Compound 4, half-maximal inhibitory concentration: 23800 nM
Compound 4: middle estimate off by 3.0-fold (0.47 log units), on the low side; the measured number lies above the stated range.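

In this assay, putting 4-methylphenyl in place of 3-fluorophenyl on the aromatic nitrogen gave a 3.7-fold higher number from compound 3 to compound 4 (0.57 log units; beyond the scatter), so the step did not carry over at the size seen on the core of compound 1. The two steps differ, which shows that the size of this change depends on the core in this pair: the same change on two cores in this assay, a 1.3-fold higher number (0.12 log units; within the scatter) from compound 1 to compound 2 and a 3.7-fold higher number (0.57 log units; beyond the scatter) from compound 3 to compound 4, 2.8-fold (0.45 log units) apart, beyond the scatter of two such steps. This does not show which feature of the cores matters, nor what size the step would take on any third core.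

The compounds shown leave open whether the larger step follows the fluorine leaving or the methyl entering, a question a plain phenyl would help to settle. From the compounds shown here alone, how an amine or a carboxylic acid on that ring would read on either core also stays open.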